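The compounds below may be only part of what the source reports. "The series", "measured", "known", "first", "only" and "open" are said of these compounds alone.

Going by the values given here, compound 2 `CCCCCCCc1cn(C(c2ccccc2)c2cc3cc(Br)ccc3nc2OC)nn1` gives 9.7% in an ADME assay on HeLa cells (Homo sapiens) for cytotoxicity, read by sulforhodamine B assay, with a stated time of 48 h, tested at 10 uM; on this read-out lower numbers stand for less inhibition and higher numbers for more inhibition at the one concentration tested (going by the name of the read-out); the only other number measured there, that of compound 1 `COc1nc2ccc(Br)cc2cc1C(c1ccccc1)n1cc(-c2ccc(Br)cc2)nn1`, which gives 6.92%, differs from it only within the scatter. That one measured step, a number 2.8 percentage points higher from compound 1 to compound 2 (within the scatter), came from heptyl in place of 4-bromophenyl on an aromatic carbon and stayed within the scatter. Compound 3 `CCCCCCc1cn(C(c2ccccc2)c2cc3cc(Br)ccc3nc2OC)nn1` differs from compound 2 by hydrogen in place of methyl on a saturated chain carbon, six bonds along the chain from an aromatic carbon. Since the much larger exchange gave no movement beyond the scatter, none is expected here either, and the expected step is a number 0.7 percentage points lower from compound 2 to compound 3 (within the scatter). Compound 3 is therefore estimated at 9%, between 0% and 20%.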

Compound 3, a percentage reported as inhibition, at one concentration (the size of the read-out at that concentration, not a potency): -0.97%
Compound 3: the middle estimate sits 10 percentage points above what was measured; measured number outside the range, below it.
By their numbers in this assay, from the lowest: compounds 3, 1 and 2 (each within the scatter of the next, the first and the last beyond it).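

Removing one methyl on a saturated chain carbon, six bonds along the chain from an aromatic carbon, gave a number 10.7 percentage points lower from compound 2 to compound 3 (beyond the scatter) in this assay, so this small change moved the number beyond the scatter where the larger exchange of 4-bromophenyl for heptyl had not. Hexyl in place of 4-bromophenyl gave a number 7.9 percentage points lower from compound 1 to compound 3 (within the scatter) and so stayed within it. Nothing at hand accounts for the difference between heptyl and hexyl. The compounds shown leave open whether butyl or octyl would continue this trend. They also leave open how a chain carrying an amine would read here.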